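This account rests on a few compounds, and the source may have more. Where it says the series, first, only, none or still open, it means among the compounds named here.

Compound 1 `COc1ccc(C2=NN(C3=NC(=O)/C(=C4\C(=O)Nc5ccccc54)S3)C(c3ccc(OC)cc3)C2)cc1` gives 99600 nM in a functional assay on cells (Cancer cell lines, Homo sapiens) for cytotoxicity, read by sulforhodamine B assay, with a stated time of 48 h; on this read-out higher numbers stand for weaker inhibition of growth and lower numbers for stronger inhibition of growth.
Compound 2 `COc1ccc(C2CC(c3ccc4ccccc4c3)=NN2C2=NC(=O)/C(=C3\C(=O)Nc4ccccc43)S2)cc1` gives 32800 nM.
Compound 3 `COc1ccc(C2CC(c3ccc4ccccc4c3)=NN2C2=NC(=O)/C(=C3\C(=O)Nc4ccc(Br)cc43)S2)cc1` gives 990 nM.

Among these three numbers compound 2 stands second highest. Its nearest neighbour is reached by the step of a 3.0-fold lower number from compound 1 to compound 2 (0.48 log units; beyond the scatter), its furthest by the step of a 33-fold lower number from compound 2 to compound 3 (1.52 log units; beyond the scatter).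

Compound 4 `O=C1N=C(N2N=C(c3ccc4ccccc4c3)CC2c2ccc(Cl)cc2)S/C1=C1/C(=O)Nc2ccccc21` differs from compound 2 in one place: chloro in place of methoxy on an aromatic carbon. Neither measured step touches this group. The step of a 3.0-fold lower number from compound 1 to compound 2 (0.48 log units; beyond the scatter) swaps a whole ring elsewhere in the molecule, and the step of a 33-fold lower number from compound 2 to compound 3 (1.52 log units; beyond the scatter) adds bromo on a different ring. With no measured change at this position, the expectation for compound 4 is a step of no size beyond the scatter, that is a 1.3-fold lower number from compound 2 to compound 4 (0.12 log units; within the scatter). Compound 4 is therefore estimated at 25000 nM, within a range from 6000 nM to 100000 nM.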

Compound 4, concentration for total growth inhibition: 38300 nM
Compound 4: the middle estimate sits 1.5-fold (0.19 log units) below what was measured; the range from low to high includes it.
By their numbers in this assay, from the lowest: compound 3; then compounds 2 and 4 (each within the scatter of the next); then compound 1.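

Going by these compounds alone, replacing methoxy with chloro on this ring gives a 1.2-fold higher number from compound 2 to compound 4 (0.07 log units; within the scatter) in this assay, the first look at a position that no earlier step touched. On the shared core of compound 2 and compound 4, then, a two-atom group with an oxygen and a single chlorine atom give numbers that cannot be told apart. Nothing available explains why these two groups read alike.

Going by these compounds, whether an amine or a carboxylic acid at this place would also read alike remains open. So does whether chloro would match methoxy with the bromo of compound 3 present.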